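Swapping Cyclopropyl for Methoxyethyl on a Sulfonamide Nitrogen

This account rests on a few compounds, and the source may have more. Where it says the series, first, only, none or still open, it means among the compounds named here.

Compound 1, `O=C(NO)c1ccc(CN(C2CC2)S(=O)(=O)c2cc(F)c(F)c(F)c2F)cc1`, was tested in an assay on Sf9 cells for inhibition of histone deacetylase 8 (Homo sapiens), read by fluorescence and mobility shift assay; on this read-out lower numbers stand for stronger inhibition and higher numbers for weaker inhibition. In this assay compound 1 gives only a limit, > 1000 nM, not a measured number. Compound 2, `CC(C)N(Cc1ccc(C(=O)NO)cn1)S(=O)(=O)c1cc(F)c(F)c(F)c1F`, is a close relative built on a different core. In this assay compound 2 likewise gives only a limit, > 1000 nM. Both results therefore sit at the same boundary, and neither reveals how far beyond it the true inhibition lies.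

Compound 3, `COCCN(Cc1ccc(C(=O)NO)cc1)S(=O)(=O)c1cc(F)c(F)c(F)c1F`, has not yet been measured. It differs from compound 1 in a single place: 2-methoxyethyl in place of cyclopropyl on a sulfonamide nitrogen. Among the compounds with values here, no step between two measured compounds is available for comparison, so the size of this change can only be estimated. Since compound 1 already sits at the limit of > 1000 nM in this assay, at which 2 of the 2 values shown sit, compound 3 is expected to end up in the same region, with an expected step that the limit leaves unreadable from compound 1 to compound 3 that stays within the usual scatter. The estimate for compound 3 in this assay is 3000 nM, with a range from 800 nM to 20000 nM, and a real chance that only a limit is reported again.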

Compound 3, half-maximal inhibitory concentration: > 1000 nM
Compound 3 gave a limit, no number; the forecaster's own chance of this, stated with the estimate: 75%; the middle value lies beyond the limit too.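

In this assay compound 3 gives only a limit, just as compound 1 does, so no step between compound 1 and compound 3 can be read: the limit of > 1000 nM in this assay, at which 3 of the 3 values shown sit.

The compounds shown leave open how far beyond that limit each true value lies, and whether 2-methoxyethyl in place of cyclopropyl on a sulfonamide nitrogen changes inhibition at all.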